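The compounds below may be only part of what the source reports. "The series", "measured", "known", "first", "only" and "open" are said of these compounds alone.

Within the data shown here, in a functional assay on cells (Erythrocyte, Rattus norvegicus) for inhibition, read by hemolysis, with a stated time of 1 h (on this read-out higher numbers stand for weaker inhibition and lower numbers for stronger inhibition), compound 1 (`COc1cc(OC)c(OC)cc1/C=C/C(=O)c1cc(OC(C)=O)ccc1OC(C)=O`) gives 2.33 ug/mL and compound 2 (`COc1cc(OC)c(OC)cc1/C=C/C(=O)c1ccccc1`) gives 2.23 ug/mL, so compound 2 lies within the usual scatter of the only other measured compound. Compound 3 (`COc1cc(OC)c(OC)cc1/C=C/C(=O)c1ccc(F)cc1`) differs from compound 2 in one place, fluoro in place of hydrogen on an aromatic carbon. Among the measured compounds shown here, no pair of measured compounds shows this change in this assay. The estimated step of a 1.0-fold lower number from compound 2 to compound 3 (0.01 log units; within the scatter) is therefore expected to stay within the scatter, in neither direction. For compound 3 the expected value is 2.2 ug/mL, with an estimated range of 1 ug/mL to 5 ug/mL.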

Compound 3, half-maximal inhibitory concentration: 2.22 ug/mL
Estimate against measurement, compound 3: 1.0-fold (0.00 log units) below, and the stated range covers the measured number.
By their numbers in this assay, from the lowest: compounds 3, 2 and 1 (each within the scatter of the next).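

In this assay the change from phenyl to 4-fluorophenyl gives a 1.0-fold lower number from compound 2 to compound 3 (0.00 log units; within the scatter) and so leaves the number within the scatter. Among these compounds, this is the first step that can be read at a single place, and it shows that fluoro on this aromatic carbon, para to a large group, is tolerated in place of hydrogen. No measurement given here bears on this result.

From the compounds shown here alone, whether an amine, a carboxylic acid or a longer chain in this same place would also stay within the scatter remains open.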